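A few compounds are considered here, and "the series" means these few. Any claim that something is new, unique, unknown or untested is made for them only; others in the source may bear on it.

Working notes on the series, all read in a functional assay on MHCC97H cells (Homo sapiens) for antiproliferative activity, read by MTT assay, with a stated time of 48 h; a higher number here means a weaker inhibitor, a lower number a stronger inhibitor. Compound 1 (`COc1ccc2c(/C=C/C(=O)c3cc(OC)c(OC)c(SC)c3)c[nH]c2c1`) gives 112 nM, compound 2 (`COc1ccc2c(/C=C/C(=O)c3cc(OC)c(OC)c([N+](=O)[O-])c3)c[nH]c2c1`) gives 289 nM and compound 3 (`COc1cc(C(=O)/C=C/c2c[nH]c3ccccc23)cc(SC)c1OC`) gives 131 nM. Among the measured compounds shown here, no measured compound has a number clearly lower than that of compound 1. Its nearest neighbour is level with it: a 1.2-fold higher number from compound 1 to compound 3 (0.07 log units; within the scatter). Its furthest neighbour lies beyond the scatter: a 2.6-fold higher number from compound 1 to compound 2 (0.41 log units; beyond the scatter).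

Compound 4 (`COc1ccc2c(/C=C/C(=O)c3cc(OC)c(OC)c(SC)c3)cn(C)c2c1`) carries one change from compound 1: methyl in place of hydrogen on an aromatic nitrogen. For the measured compounds named here, the aromatic nitrogen bears hydrogen in all three measured compounds, so no measured step tests this change directly. The two steps above exchange other groups, nitro for methylsulfanyl and hydrogen for methoxy, and they show only how far single exchanges have moved the number in this small set. They give no direction for the new methyl. The working expectation in this assay is therefore no step beyond the scatter, with a wide margin on both sides. The step expected on this basis is a 1.1-fold lower number from compound 1 to compound 4 (0.05 log units; within the scatter). For compound 4 the estimated value is 100 nM, with an expected range of 30 nM to 300 nM.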

Compound 4, half-maximal inhibitory concentration: 122 nM
Compound 4: the middle estimate sits 1.2-fold (0.09 log units) below what was measured; low and high end bracket the measured number.
By their numbers in this assay, from the lowest: compounds 1, 4 and 3 (each within the scatter of the next); then compound 2.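

In this assay, among the compounds shown here, methyl in place of hydrogen on the aromatic nitrogen gives the first direct reading at this position (this step is a 1.1-fold higher number from compound 1 to compound 4 (0.04 log units; within the scatter)), which bore hydrogen in all three earlier compounds: on the core of compound 1, the hydrogen there can be exchanged for methyl without a step beyond the scatter. This change therefore joins hydrogen in place of methoxy on an aromatic carbon (a 1.2-fold higher number from compound 1 to compound 3 (0.07 log units; within the scatter)) as a second single exchange that stays within the scatter, while nitro in place of methylsulfanyl (a 2.6-fold higher number from compound 1 to compound 2 (0.41 log units; beyond the scatter)) remains the only step shown that goes beyond it. Nothing measured here explains why the number holds when the methyl enters.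

The compounds shown leave open how far this nitrogen accepts other groups, such as an ethyl group, a longer chain, or a chain ending in an amine or a carboxylic acid. They also leave open whether methyl on this nitrogen would give a similar step from compound 2 or compound 3, where the groups on the rest of the core differ.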